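From cyclopentylamino to cyclohexylamino, starting from a limit

A few compounds are considered here, and "the series" means these few. Any claim that something is new, unique, unknown or untested is made for them only; others in the source may bear on it.

Compound 1 `Nc1nc(OCc2ccccc2)c2ncn(/C=C3/CC3(CO)CO)c2n1`: > 20000 nM (a limit)
Compound 2 `Nc1nc(NC2CCCC2)c2ncn(/C=C3/CC3(CO)CO)c2n1`: > 20000 nM (a limit)

Both compounds were tested in an ADME assay on Akata cells (Homo sapiens) for cytotoxicity, with a stated time of 7 days; a higher number here means that more compound is tolerated, a lower number that less compound is tolerated. Compound 1 gives > 20000 nM, which is a limit of the assay and not a number. Compound 2 gives > 20000 nM, which is likewise a limit. For the measured compounds named here, compound 2 therefore has no readable position, and the only other value shown is also a limit. The whole record so far is the limit of > 20000 nM in this assay, at which 2 of the 2 values shown sit.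

Compound 3 `Nc1nc(NC2CCCCC2)c2ncn(/C=C3/CC3(CO)CO)c2n1` differs from compound 2 in one group: cyclohexyl in place of cyclopentyl on a nitrogen on an aromatic ring. In words, cyclohexyl stands in place of cyclopentyl on a nitrogen on an aromatic ring. Going by the values given here, the only measured step is a step that the two limits leave unreadable from compound 1 to compound 2, which put cyclopentylamino in place of benzyloxy on an aromatic carbon. Among the compounds with values here, with that step as the only guide, no change beyond the scatter is expected in this assay, and no direction can be given. The expected step is a number no higher from compound 2 to compound 3 (the limit leaves the size open). Compound 3 is estimated at 20000 nM, with an expected range from 9000 nM to 45000 nM. A further limit instead of a number is the likeliest expected outcome.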

Compound 3, half-maximal cytotoxic concentration: > 24000 nM
Compound 3: only a limit was reported (the forecaster's own chance of this, stated with the estimate: 80%); middle value at least 1.2-fold (0.07 log units) from the limit.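

In this assay compound 3 gives > 24000 nM, which is a limit of the assay and not a number. For the compounds shown here, no step between compound 1, compound 2 and compound 3 can be read. The compounds shown leave open where the half-maximal cytotoxic concentration of each lies, and whether benzyloxy, cyclopentylamino and cyclohexylamino differ at all in this assay.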